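This account rests on a few compounds, and the source may have more. Where it says the series, first, only, none or still open, it means among the compounds named here.

Measured in an in vitro functional assay on cells for agonist activity at Bombesin receptor subtype-3 (Homo sapiens), read by luminescence and calcium flux; on this read-out higher numbers stand for an effect only at larger amounts of compound and lower numbers for an effect already at smaller amounts:
compound 1 `COc1cccc(Cc2cnc(CCc3ccc(-c4ccccc4C(=O)O)cc3)[nH]2)c1` gives 4120 nM
compound 2 `O=C(O)c1ccccc1-c1ccc(CCc2ncc(Cc3ccccc3F)[nH]2)cc1` gives 177 nM
compound 3 `CC(C)(C)CCc1cnc(CCc2ccc(-c3ccccc3C(=O)O)cc2)[nH]1` gives 39 nM

Compound 3 stands lowest of the three measured numbers: a 4.5-fold lower number from compound 2 to compound 3 (0.66 log units; beyond the scatter), and a 110-fold lower number from compound 1 to compound 3 (2.02 log units; beyond the scatter). Compound 4 `COc1ccccc1Cc1cnc(CCc2ccc(-c3ccccc3C(=O)O)cc2)[nH]1` differs from compound 3 by 2-methoxyphenyl in place of neopentyl on a saturated chain carbon bound to an aromatic carbon. Among the compounds with values here, two measured steps bear directly on this change, since they are the same kind of swap run the other way: a 110-fold lower number from compound 1 to compound 3 (2.02 log units; beyond the scatter) and a 4.5-fold lower number from compound 2 to compound 3 (0.66 log units; beyond the scatter), both large. The third step, a 23-fold lower number from compound 1 to compound 2 (1.37 log units; beyond the scatter), shows that the choice of ring group matters nearly as much. The 2-methoxyphenyl of compound 4 resembles both the 3-methoxyphenyl of compound 1 and the 2-fluorophenyl of compound 2, so a rise somewhere between those two outcomes is expected. Going to compound 4 the number is therefore expected to rise: a 10-fold higher number from compound 3 to compound 4 (1.01 log units; beyond the scatter). For compound 4 the estimate is 400 nM, within 80 nM to 2500 nM.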

Compound 4, half-maximal effective concentration: 1720 nM
Compound 4: the middle estimate sits 4.3-fold (0.63 log units) below what was measured, and the stated range covers the measured number.
By their numbers in this assay, from the lowest: compound 3; then compound 2; then compound 4; then compound 1.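

With a 44-fold higher number from compound 3 to compound 4 (1.64 log units; beyond the scatter) as the cost, compound 4 shows that a 2-methoxyphenyl, like the 3-methoxyphenyl of compound 1, does far worse than neopentyl at this position. The ring's substituent also counts: methoxy in place of fluoro on an aromatic carbon gives a 9.7-fold higher number from compound 2 to compound 4 (0.99 log units; beyond the scatter) and 2-methoxyphenyl in place of 3-methoxyphenyl gives a 2.4-fold lower number from compound 1 to compound 4 (0.38 log units; beyond the scatter) without reaching the low number of compound 2. No measurement shown explains these differences.

On these data alone, whether an unsubstituted phenyl would sit closer to compound 2 remains open. So does whether a longer chain or an amine could match neopentyl here.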